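Shortening the phenyl-bearing chain: working notes

A few compounds are considered here, and "the series" means these few. Any claim that something is new, unique, unknown or untested is made for them only; others in the source may bear on it.

Three members of the series have been run in a functional assay on NCI-H630 cells (Homo sapiens) for cytotoxicity, read by sulforhodamine B assay, with a stated time of 5 days; a higher number here means a weaker inhibitor, a lower number a stronger inhibitor. Compound 2 `O=C(CCCCCCc1ccccc1)CC(=O)N[C@H]1CCOC1=O` gives 65000 nM. Compound 3 `O=C(CCCCCCCCCCc1ccccc1)N[C@H]1CCOC1=O` gives 70000 nM, and the two values sit within the scatter of each other. The difference between the core of compound 2 and the core of compound 3 is not broken down here. Compound 1 `O=C(CCCCc1ccccc1)CC(=O)N[C@H]1CCOC1=O` gives only a limit of the assay, > 100000 nM. That value is the limit of > 100000 nM in this assay, at which 1 of the 3 values shown sits. The change from compound 2 to compound 1 is phenyl in place of phenethyl on a saturated chain carbon, four bonds along the chain from a carbonyl carbon, and it made a step of an at least 1.5-fold higher number from compound 2 to compound 1 (0.18 log units; that floor lies within the scatter).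

Compound 4 `O=C(CCCCCCCCc1ccccc1)N[C@H]1CCOC1=O` has not yet been measured. It arises from compound 3 by phenyl in place of phenethyl on a saturated chain carbon, eight bonds along the chain from a carbonyl carbon, the same kind of change as that from compound 2 to compound 1, though the place differs: eight bonds along the chain from a carbonyl carbon rather than four bonds along the chain from a carbonyl carbon. Within the data shown here, a step of like direction is expected from compound 3 to compound 4, a 1.6-fold higher number from compound 3 to compound 4 (0.20 log units; within the scatter), resting on an at least 1.5-fold higher number from compound 2 to compound 1 (0.18 log units; that floor lies within the scatter) as the only measured instance of this kind of change, which is a thin basis. For compound 4 the expected value is 110000 nM, between 50000 nM and 300000 nM, with a fair chance that the assay returns only a limit.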

Compound 4, half-maximal inhibitory concentration: > 100000 nM
Compound 4: only a limit was reported; the forecaster's own chance of this, stated with the estimate: 45%; the middle value is on the limit's open side.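

In this assay, phenyl in place of phenethyl on a saturated chain carbon, eight bonds along the chain from a carbonyl carbon, gives an at least 1.4-fold higher number from compound 3 to compound 4 (0.15 log units; that floor lies within the scatter). Set beside the earlier case, the change points the same way on both cores, but neither reading fixes a size, so no difference or equality between the cores can be claimed: the same change on two cores in this assay, an at least 1.5-fold higher number (0.18 log units; that floor lies within the scatter) from compound 2 to compound 1 and an at least 1.4-fold higher number (0.15 log units; that floor lies within the scatter) from compound 3 to compound 4; the limit leaves it open whether they differ Two cores give a thin basis for carrying the change further, and neither floor alone lies beyond the scatter, so the true size of the step on either core remains unknown: the limit of > 100000 nM in this assay, at which 2 of the 4 values shown sit.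

The compounds shown leave open how far beyond the limit the compounds with the shorter chains lie, and so whether chain length matters at all on either core. They also leave open whether a longer chain on the core of compound 2 or on the core of compound 3, or an amine or a carboxylic acid in place of the terminal phenyl, would move the number in this assay clearly beyond the scatter.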